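Methyl for Hydrogen on the Aryl Ring: Whole-Organism Inhibition

The source may hold more compounds than are shown below. What is called first, only, known or untested is meant among the compounds shown, and "the series" means these compounds.

Measured compounds:
Compound 1, `O=C(O)CCC1=C(c2ccc(Cl)cc2)NC(=S)NC1c1ccco1`: 5.52%
Compound 2, `O=C(O)CCC1=C(c2ccccc2)NC(=S)NC1c1ccco1`: 9.81%

In a functional assay on the whole organism (strain Albino) for inhibition, with Rattus norvegicus as the target, with stated times of 1 h and 3 h, at a dose of 20 mg/kg by the oral route (a higher number here means more inhibition at the dose given (going by the name of the read-out), a lower number less inhibition), compound 2 gives 9.81%, the larger of the two numbers shown, though its gap to compound 1 at 5.52% is within the scatter. Among the measured compounds shown here, the single measured step, a number 4.3 percentage points higher from compound 1 to compound 2 (within the scatter), is likewise within the scatter. Compound 3, `Cc1ccc(C2=C(CCC(=O)O)C(c3ccco3)NC(=S)N2)cc1`, differs from compound 2 by methyl in place of hydrogen on an aromatic carbon. Only the chloro-to-hydrogen step speaks to a change on this aromatic carbon, and it was small, so no step beyond the scatter is expected in this assay. The expected step of a number 0.2 percentage points higher from compound 2 to compound 3 (within the scatter) is within the scatter. Compound 3 is estimated at 10%, with a range from 2% to 20%.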

Compound 3, a percentage reported as inhibition, in the whole organism at one dose (the size of the read-out at that dose, not a potency): 10.4%
Estimate against measurement, compound 3: 0.4 percentage points below, and the stated range covers the measured number.
By their numbers in this assay, from the lowest: compounds 1, 2 and 3 (each within the scatter of the next).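

In this assay the step of a number 0.6 percentage points higher from compound 2 to compound 3 (within the scatter) for methyl in place of hydrogen and the step of a number 4.9 percentage points higher from compound 1 to compound 3 (within the scatter) for methyl in place of chloro both stay within the scatter. Hydrogen, chloro and methyl have now all been compared on this aromatic carbon, para to a large group, and no step among them goes beyond the scatter. Nothing measured here offers an explanation for this result.

Open, going by these compounds, is whether an amine, a hydroxyl or a longer chain at this carbon would give a step beyond the scatter. Also open, on these data alone, is whether a change elsewhere on the shared core would do so.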